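The source may hold more compounds than are shown below. What is called first, only, known or untested is meant among the compounds shown, and "the series" means these compounds.

Compound 1 `N#Cc1c(-c2ccccc2)c(C#N)c(=O)n(/N=C/c2cn(-c3ccccc3)nc2-c2ccccc2)c1N`: 180 ug/mL
Compound 2 `N#Cc1c(-c2ccccc2Cl)c(C#N)c(=O)n(/N=C/c2cn(-c3ccccc3)nc2-c2ccccc2)c1N`: 84 ug/mL
Compound 3 `N#Cc1c(-c2cccc(Cl)c2)c(C#N)c(=O)n(/N=C/c2cn(-c3ccccc3)nc2-c2ccccc2)c1N`: 52 ug/mL

These three numbers come from an ADME assay on NIH3T3 cells (Mus musculus) for cytotoxicity, read by MTT assay; a lower number here means a stronger inhibitor, a higher number a weaker inhibitor. Compound 2 stands second highest of the three. Its nearest neighbour is compound 3, and that step, a 1.6-fold lower number from compound 2 to compound 3 (0.21 log units; within the scatter), is within the scatter, so the two cannot be ranked against each other. Its furthest neighbour is compound 1, and that step, a 2.1-fold lower number from compound 1 to compound 2 (0.33 log units; beyond the scatter), does lie beyond the scatter.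

Compound 4 `N#Cc1c(-c2cccc(F)c2)c(C#N)c(=O)n(/N=C/c2cn(-c3ccccc3)nc2-c2ccccc2)c1N` differs from compound 2 in one place: 3-fluorophenyl in place of 2-chlorophenyl on an aromatic carbon. Within the data shown here, two measured steps bear on this change. Moving the chlorine from the 2-position to the 3-position gave a 1.6-fold lower number from compound 2 to compound 3 (0.21 log units; within the scatter), within the scatter. Adding chlorine at the 3-position to the unsubstituted phenyl gave a 3.5-fold lower number from compound 1 to compound 3 (0.54 log units; beyond the scatter), a modest change. Among the measured compounds shown here, no measured pair shows fluorine in place of chlorine, so that part of the change has no precedent here. The expected step is therefore small, a 1.0-fold higher number from compound 2 to compound 4 (0.01 log units; within the scatter), with no confident direction. Compound 4 is estimated at 85 ug/mL, within a range of 42 ug/mL to 170 ug/mL.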

Compound 4, half-maximal inhibitory concentration: 154 ug/mL
Compound 4: middle estimate off by 1.8-fold (0.26 log units), on the low side; measured number inside the range.
By their numbers in this assay, from the lowest: compounds 3, 2, 4 and 1 (each within the scatter of the next, the first and the last beyond it).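

In this assay, among these compounds, the swap of 3-chlorophenyl for 3-fluorophenyl (a 3.0-fold higher number from compound 3 to compound 4 (0.47 log units; beyond the scatter)) is the first measured exchange of one halogen for the other on this ring, and it shows that the choice of halogen matters here. Fluoro in place of hydrogen (a 1.2-fold lower number from compound 1 to compound 4 (0.07 log units; within the scatter)) leaves compound 4 unresolved from the unsubstituted phenyl of compound 1, whereas chloro in place of hydrogen (a 3.5-fold lower number from compound 1 to compound 3 (0.54 log units; beyond the scatter)) gave a step beyond the scatter. Compound 4 also cannot be ranked against compound 2 (a 1.8-fold higher number from compound 2 to compound 4 (0.26 log units; within the scatter)), so moving from 2-chlorophenyl to 3-fluorophenyl gives no readable change. Nothing available explains the difference between the two halogens. From the compounds shown here alone, whether a bromine, a methoxy group or an amine on this phenyl ring would follow chloro or fluoro remains open.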